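From indolyl to 4-acetylphenyl on the shared core

The source may hold more compounds than are shown below. What is called first, only, known or untested is meant among the compounds shown, and "the series" means these compounds.

Measured in a functional assay on A549 cells (Homo sapiens) for inhibition, read by CCK-8 assay, with a stated time of 48 h; a higher number here means a weaker inhibitor, a lower number a stronger inhibitor:
Compound 1 `COc1cc(-c2ccnc3cc(-c4ccccc4)nn23)cc(OC)c1OC`: 208 nM
Compound 2 `COc1cc(-c2ccnc3cc(-c4cn(C)c5ccccc45)nn23)cc(OC)c1OC`: 1340 nM

Of the two, compound 2 stands highest, at 1340 nM. Compound 3 `COc1cc(-c2ccnc3cc(-c4ccc(C(C)=O)cc4)nn23)cc(OC)c1OC` is unmeasured. Its difference from compound 2 is 4-acetylphenyl in place of 1-methyl-1H-indol-3-yl on an aromatic carbon. Going by the values given here, the only measured step bearing on this is a 6.4-fold higher number from compound 1 to compound 2 (0.81 log units; beyond the scatter), a modest one that also involves 1-methyl-1H-indol-3-yl. Among the compounds with values here, no measured compound carries the acetyl group, so a step toward a lower number in this assay is expected, somewhat smaller than that one. The expected change is a 3.8-fold lower number from compound 2 to compound 3 (0.58 log units; beyond the scatter). The estimate for compound 3 is 350 nM, with a range from 100 nM to 1200 nM.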

Compound 3, half-maximal inhibitory concentration: 4100 nM
For compound 3 the middle estimate is 12-fold (1.07 log units) below the measured one; measured number above the stated range.
By their numbers in this assay, from the lowest: compound 1; then compound 2; then compound 3.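

In this assay, adding acetyl in place of hydrogen on an aromatic carbon gives a 20-fold higher number from compound 1 to compound 3 (1.29 log units; beyond the scatter), a large loss that shows this phenyl group does not accept the acetyl substituent well. Replacing 1-methyl-1H-indol-3-yl with 4-acetylphenyl gives a 3.1-fold higher number from compound 2 to compound 3 (0.49 log units; beyond the scatter), so both replacements of phenyl at this carbon weaken inhibition, and the acetyl change does so more. Nothing available explains these steps.

As far as these compounds go, it remains open whether this loss is specific to acetyl or extends to other substituents on the phenyl ring, such as a methoxy group, an amine or a carboxylic acid.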